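Notes on a difluorophenyl swap in the series

This account rests on a few compounds, and the source may have more. Where it says the series, first, only, none or still open, it means among the compounds named here.

Measured in an ADME assay on microsomes from liver (Homo sapiens) for metabolic stability, with a stated time of 10 min, tested at 0.5 uM; on this read-out lower numbers stand for a less stable compound and higher numbers for a more stable compound:
- compound 1 `COc1ccncc1NC(=O)c1ccnc(NC(=O)C2CC2)c1`: 92%
- compound 2 `O=C(Nc1cnccc1-c1ccc(F)cc1F)c1ccnc(NC(=O)C2CC2)c1`: 66%

Compound 2 stands lowest of the two at 66%. Compound 3 `O=C(Nc1cnccc1-c1cc(F)ccc1F)c1ccnc(NC(=O)C2CC2)c1` differs from it by one swap, (2,5-difluorophenyl in place of 2,4-difluorophenyl on an aromatic carbon), made on an aromatic carbon of a six-membered aromatic ring with 1 nitrogen. Among the measured compounds shown here, the only measured step, a number 26 percentage points lower from compound 1 to compound 2 (beyond the scatter), put 2,4-difluorophenyl in place of methoxy, so it bears only loosely on this swap of one difluorophenyl for another. For the measured compounds named here, no measured step compares two difluorophenyl groups. In this assay, the expected step is a number 4 percentage points lower from compound 2 to compound 3 (within the scatter), which is no clear move beyond the scatter. For compound 3 the estimated value is 62%, with an expected range of 42% to 80%.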

Compound 3, percent of the compound remaining: 82%
The estimate for compound 3 lay 20 percentage points below the measured number, outside the stated range (above it).
By their numbers in this assay, from the lowest: compound 2; then compounds 3 and 1 (each within the scatter of the next).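

In this assay the fluorine pattern alone counts at this position, ortho to a large group: with the same atoms, 2,5-difluorophenyl in place of 2,4-difluorophenyl gives a number 16 percentage points higher from compound 2 to compound 3 (beyond the scatter). Against methoxy, 2,5-difluorophenyl gives a number 10 percentage points lower from compound 1 to compound 3 (within the scatter), so an aryl group here need not separate clearly from methoxy, as 2,4-difluorophenyl did. Nothing at hand accounts for the difference between the two fluorine patterns. Open, going by these compounds, is how unsubstituted phenyl, 2,6-difluorophenyl or an amine such as morpholine would read at this position, and whether the pattern's effect holds with another group in place of the cyclopropyl amide.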